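Halogenated Phenyl Swap and Dog Microsome Stability

A few compounds are considered here, and "the series" means these few. Any claim that something is new, unique, unknown or untested is made for them only; others in the source may bear on it.

Compound 1 `N#Cc1ccc(-c2nc(NCCNc3ccc([N+](=O)[O-])c(N)n3)ncc2-c2ncc[nH]2)cc1`: in an ADME assay on microsomes from liver (Canis lupus familiaris) for metabolic stability (on this read-out lower numbers stand for a shorter-lived compound and higher numbers for a longer-lived compound), compound 1 gives > 0.5 h, a limit of the assay.
Compound 2 `Nc1nc(NCCNc2ncc(-c3ncc[nH]3)c(-c3ccc(C(F)(F)F)cc3)n2)ccc1[N+](=O)[O-]`: in this assay compound 2 gives > 0.5 h, also a limit.
Compound 3 `Nc1nc(NCCNc2ncc(-c3ncc[nH]3)c(-c3cc(F)ccc3F)n2)ccc1[N+](=O)[O-]`: in this assay compound 3 gives > 0.5 h, again a limit.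

Compound 3 therefore stands where every measured value stands, at the limit of > 0.5 h in this assay, at which 3 of the 3 values shown sit. The unmeasured compound 4 `Nc1nc(NCCNc2ncc(-c3ncc[nH]3)c(-c3ccc(Cl)cc3Br)n2)ccc1[N+](=O)[O-]` differs from compound 3 in one place: 2-bromo-4-chlorophenyl in place of 2,5-difluorophenyl on an aromatic carbon. Among the compounds with values here, no measured step exchanges these same two groups. Within the data shown here, the steps that exist, a step that the two limits leave unreadable from compound 1 to compound 2, a step that the two limits leave unreadable from compound 1 to compound 3 and a step that the two limits leave unreadable from compound 2 to compound 3, each sit between two limits and give no readable size, so no step of any size in either direction can be expected in this assay. Compound 4 is expected at 1 h, within 0.4 h to 3 h. This amounts to an expected step that the limit leaves unreadable from compound 3 to compound 4, nothing beyond the scatter.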

Compound 4, half-life: > 0.5 h
Compound 4 gave a limit, no number; the forecaster's own chance of this, stated with the estimate: 80%; the middle value lies beyond the limit too.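

Within the data shown here, compound 4 gives a limit, just as compound 1, compound 2 and compound 3 do, so no step between any of them can be read: the limit of > 0.5 h in this assay, at which 4 of the 4 values shown sit. How long each of these compounds actually lasts in this assay stays open, and with it whether exchanging the aromatic group changes the half-life at all.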